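The compounds below may be only part of what the source reports. "The series", "measured", "known", "first", "only" and "open" are said of these compounds alone.

Measured compounds:
- compound 1, `Cc1ccc(-c2cc(/N=C3/NC(=O)CS3)cs2)cc1`: > 50000 nM
- compound 2, `COc1cccc(N2C(=O)CS/C2=N\c2csc(-c3ccccc3)c2)c1`: "not determined" (no result reported)

In a functional assay on MDA-MB-231 cells (Homo sapiens) for cytotoxicity, read by MTT assay, with a stated time of 72 h (on this read-out lower numbers stand for stronger inhibition and higher numbers for weaker inhibition), compound 1 sits at a limit of the assay, > 50000 nM, not at a number. For compound 2 this assay reports "not determined" (no result reported), so there is no single number to place it. Among the compounds with values here, the only other value in the set is the one described by the limit of > 50000 nM in this assay, at which 1 of the 2 values shown sits. Compound 2 therefore stands nowhere on a numerical scale here; its position is known only as one of two entries, one a limit and one without a result.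

Compound 3, `COc1cccc(N2C(=O)CS/C2=N\c2csc(-c3ccc(C)cc3)c2)c1`, is the unmeasured member. It differs from compound 2 by methyl in place of hydrogen on an aromatic carbon. Within the data shown here, no step between measured compounds exists in this assay, so no measured size of step can be carried over. With the one value in the set being the limit of compound 1, > 50000 nM, the expectation for compound 3 is weak inhibition, and a step of any size beyond the scatter cannot be anticipated in either direction from the data shown. Compound 3 is expected at 50000 nM, in the range 15000 nM to 150000 nM, with a real chance that only a limit is reported.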

Compound 3, half-maximal inhibitory concentration: > 50000 nM
Compound 3: only a limit was reported (the forecaster's own chance of this, stated with the estimate: 65%); the middle value lies on the limit itself.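

No step can be read between compound 1 and compound 3, or from compound 2 to compound 3, as compound 1 and compound 3 sit at the same limit and compound 2 has no number: the limit of > 50000 nM in this assay, at which 2 of the 3 values shown sit.

The compounds shown leave open whether any change on the shared core gives a readable value in this assay, and what phenyl to 4-methylphenyl does there.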